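The source may report more compounds than this note shows. Statements on the series, on what has been measured and on what is new or still open speak of the compounds shown alone.

Of the compounds shown here, two built on one shared core have been measured so far. In a functional assay on cells (Platelet, Homo sapiens) for inhibition (a higher number here means a weaker inhibitor, a lower number a stronger inhibitor), compound 1 `CCOC(=O)c1ccc(-c2nn(Cc3ccc(F)cc3)c3ccccc23)cc1` gives 190 nM and compound 2 `COC(=O)c1ccc(-c2nn(Cc3ccccc3)c3ccccc23)cc1` gives 560 nM, the higher number of the two and so the weaker inhibitor, by a gap beyond the usual scatter. Compound 3 `CCNC(=O)c1ccc(-c2nn(Cc3ccccc3)c3ccccc23)cc1` has ethylamino in place of the methoxy of compound 2 on a carbonyl carbon, so methoxycarbonyl becomes ethylcarbamoyl: ethylamino in place of methoxy on a carbonyl carbon. Among the compounds with values here, neither measured compound carries this group, so no measured step guides the forecast. A moderate loss of inhibition in this assay is expected, an estimated 2.7-fold higher number from compound 2 to compound 3 (0.43 log units; beyond the scatter). For compound 3 the expected value is 1500 nM, with a likely range of 400 nM to 6000 nM.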

Compound 3, half-maximal inhibitory concentration: 5640 nM
The estimate for compound 3 lay 3.8-fold (0.58 log units) below the measured number, and the stated range covers the measured number.
By their numbers in this assay, from the lowest: compound 1; then compound 2; then compound 3.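

In this assay, replacing methoxy with ethylamino on the carbonyl carbon gives a 10-fold higher number from compound 2 to compound 3 (1.00 log units; beyond the scatter). This shows that inhibition at this position depends strongly on the group attached to the carbonyl carbon, and that methoxycarbonyl in compound 2 does better here than ethylcarbamoyl in compound 3. Nothing available here explains the loss.

Still open, going by these compounds, is how a carboxylic acid at this position would behave in this assay. Also open, on these data alone, is whether methylamino, with a shorter chain than ethylamino, or dimethylamino on the same carbonyl carbon would bring a similar loss.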